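Chloro to fluoro swap: cytotoxicity notes on four analogues

This account rests on a few compounds, and the source may have more. Where it says the series, first, only, none or still open, it means among the compounds named here.

Measured compounds in a toxicity assay on RAW264.7 cells (Mus musculus) for cytotoxicity, read by MTT assay, with a stated time of 24 h; on this read-out lower numbers stand for stronger inhibition and higher numbers for weaker inhibition:
compound 1 `C=C[C@@](C)(/C=C/c1ccc(OCc2cn(-c3ccc(Cl)cc3)nn2)cc1)CCC=C(C)C` gives 47600 nM
compound 2 `C=C[C@@](C)(/C=C/c1ccc(OCc2cn(-c3ccc(F)cc3)nn2)cc1)CCC=C(C)C` gives 233000 nM
compound 3 `C=C[C@@](C)(/C=C/c1ccc(OCc2cn(Cc3ccc(Cl)cc3)nn2)cc1)CCC=C(C)C` gives 327000 nM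

The change fluoro in place of chloro on an aromatic carbon produced a 4.9-fold higher number from compound 1 to compound 2 (0.69 log units; beyond the scatter). The cores of compound 1 and compound 3 differ by 4-chlorobenzyl in place of 4-chlorophenyl on an aromatic nitrogen, which produced a 6.9-fold higher number from compound 1 to compound 3 (0.84 log units; beyond the scatter). Compound 2 and compound 3 show a 1.4-fold higher number from compound 2 to compound 3 (0.15 log units; within the scatter).

Compound 4 `C=C[C@@](C)(/C=C/c1ccc(OCc2cn(Cc3ccc(F)cc3)nn2)cc1)CCC=C(C)C` is not yet measured in this assay. It differs from compound 3 by fluoro in place of chloro on an aromatic carbon, the same change as from compound 1 to compound 2; both place descriptions read the same word for word. A smaller step than the earlier one is expected, a 2.0-fold higher number from compound 3 to compound 4 (0.30 log units; within the scatter), because compound 3 already gives 327000 nM and compound 2 sits within scatter of it at 233000 nM, so the room for a further rise is uncertain. In this assay compound 4 is expected at 650000 nM, estimated between 250000 nM and 1800000 nM.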

Compound 4, half-maximal inhibitory concentration: 157000 nM
Estimate against measurement, compound 4: 4.1-fold (0.62 log units) above, and the stated range ends above it.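

In this assay, fluoro in place of chloro does not carry from the core of compound 1 to the core of compound 3, with the two steps running in opposite directions: the same change on two cores in this assay, a 4.9-fold higher number (0.69 log units; beyond the scatter) from compound 1 to compound 2 and a 2.1-fold lower number (0.32 log units; beyond the scatter) from compound 3 to compound 4, 10-fold (1.01 log units) apart, beyond the scatter of two such steps

On the core of compound 3 the swap gives a 2.1-fold lower number from compound 3 to compound 4 (0.32 log units; beyond the scatter), while 4-fluorobenzyl in place of 4-fluorophenyl gives a 1.5-fold lower number from compound 2 to compound 4 (0.17 log units; within the scatter), and 4-fluorobenzyl in place of 4-chlorophenyl gives a 3.3-fold higher number from compound 1 to compound 4 (0.52 log units; beyond the scatter). With one pair on each core, this shows that the swap depends on the core here, but it gives no cause and no rule for any further core.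

Still open, on these data alone, is how a bromo or methoxy group on the same aromatic carbon would behave. Also open, as far as these compounds go, is whether a phenethyl group on the aromatic nitrogen would follow the 4-chlorophenyl or the 4-chlorobenzyl compounds.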